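Inverting the lactone stereocentre of compound 1

This account rests on a few compounds, and the source may have more. Where it says the series, first, only, none or still open, it means among the compounds named here.

Compound 1 `O=C(CCc1ccccc1)N[C@H]1COC1=O` is assessed in an assay on HEK293 cells for inhibition of N-acylethanolamine-hydrolyzing acid amidase (Rattus norvegicus), with a stated time of 30 min (a higher number here means a weaker inhibitor, a lower number a stronger inhibitor), where compound 1 gives 420 nM. Among the measured compounds shown here, the only other measured member, compound 2 `CCOC(=O)c1ccc2cc(C(=O)N[C@H]3COC3=O)ccc2c1`, gives 300 nM in this assay; the two numbers lie within the scatter of each other, so compound 1 is not separated from compound 2. Compound 3 `O=C(CCc1ccccc1)N[C@@H]1COC1=O` is not yet measured. Its difference from compound 1: the two compounds have the same atoms and bonds and differ only in configuration as drawn: 1 of 1 stereo elements differ; a stereocentre at a saturated ring carbon is drawn S in compound 1 and R in compound 3. For the measured compounds named here, no measured pair in the set shows such a change, so the direction rests on expectation alone. Inverting the sole stereocentre is expected to weaken inhibition, with a step of a 7.1-fold higher number from compound 1 to compound 3 (0.85 log units; beyond the scatter). Compound 3 is therefore expected at 3000 nM, between 800 nM and 15000 nM.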

Compound 3, half-maximal inhibitory concentration: 6000 nM
For compound 3 the middle estimate is 2.0-fold (0.30 log units) below the measured one, and the stated range covers the measured number.
By their numbers in this assay, from the lowest: compounds 2 and 1 (each within the scatter of the next); then compound 3.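

Inverting the stereocentre gives a 14-fold higher number from compound 1 to compound 3 (1.15 log units; beyond the scatter) in this assay, the first step in the series that lies beyond the scatter. Configuration at this saturated ring carbon therefore matters for inhibition, and the S form as drawn is the stronger of the two. The step can be assigned to this centre alone: the fact that compounds 1 and 3 differ only in the configuration as drawn.

As far as these compounds go, whether the same preference holds for the acyl side of compound 2 remains open. Also open, from the compounds shown here alone, is how a longer alkyl chain or a terminal carboxylic acid on the side chain of compound 1 would fare in either configuration.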